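The compounds below may be only part of what the source reports. "The series", "measured", "known", "first", "only" and "open" are said of these compounds alone.

Compound 1 `Cn1c(-c2ccccc2)nc2c(NC3CCCC3)ncnc21` is the starting point of this account. In a functional assay on CHO cells for antagonist activity at adenosine receptor A2b (Homo sapiens), read by 33P incorporation, with a stated time of 20 min (a lower number here means a stronger inhibitor, a higher number a weaker inhibitor), compound 1 gives 8510 nM, the lowest of the two numbers recorded. Compound 2 `Cn1c(-c2ccc(O)cc2)nc2c(NC3CCCC3)ncnc21` carries a hydroxy in place of hydrogen on an aromatic carbon of the same core, and in this assay compound 2 gives 17800 nM, so that a 2.1-fold higher number from compound 1 to compound 2 (0.32 log units; beyond the scatter). Compound 3 `Cn1c(-c2cccnc2)nc2c(NC3CCCC3)ncnc21` carries pyridin-3-yl in place of phenyl, and in this assay compound 3 reaches only a limit of the method, > 30000 nM; that limit is the limit of > 30000 nM in this assay, at which 1 of the 3 values shown sits. Accordingly an at least 3.5-fold higher number from compound 1 to compound 3 (0.54 log units; beyond the scatter).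

The unmeasured compound 4 `Cn1c(-c2ccc(Cl)cc2)nc2c(NC3CCCC3)ncnc21` differs from compound 1 by a single change: chloro in place of hydrogen on an aromatic carbon. The step from compound 1 to compound 2 touches the same aromatic carbon and is the one that bears most directly on it; it was modest and toward a weaker inhibitor, yet it introduced a hydroxy, which is not a chloro. The step from compound 1 to compound 3 alters the ring itself and so bears less. Within the data shown here, no measured compound carries a chloro, so the direction for compound 4 is left open, and the expectation for compound 4 is a step of a 1.1-fold lower number from compound 1 to compound 4 (0.05 log units; within the scatter), within the usual scatter. On that basis compound 4 is estimated at 7500 nM in this assay, with a range from 3000 nM to 20000 nM.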

Compound 4, inhibition constant: > 30000 nM
Compound 4 ended at the assay's limit; the forecaster's own chance of this, stated with the estimate: 10%; at least 4.0-fold (0.60 log units) between middle value and limit.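

In this assay compound 4 gives > 30000 nM, which is a limit of the assay and not a number, and it is not alone there: the limit of > 30000 nM in this assay, at which 2 of the 4 values shown sit.

Chloro in place of hydrogen on this aromatic carbon, para to a large group, gives an at least 3.5-fold higher number from compound 1 to compound 4 (0.54 log units; beyond the scatter), so that now both groups shown at this place, hydroxy in compound 2 and chloro in compound 4, give a higher number than the hydrogen of compound 1, each by a step beyond the scatter. Between these two groups the reading is an at least 1.6-fold higher number from compound 2 to compound 4 (0.22 log units; that floor lies within the scatter), a floor too small to rank chloro against hydroxy, and the step between compound 3 and compound 4 cannot be read, since both values are limits.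

Going by these compounds, how far the true value of compound 4 lies past its limit stays open, and so does the full size of its step from the hydrogen of compound 1. Also open, on these data alone, is whether a fluoro, a methoxy, an amine or a carboxylic acid on this same aromatic carbon would match compound 1, give a lower number, or also reach the limit.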